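The compounds below may be only part of what the source reports. "The series", "measured", "known", "first", "only" and "open" are said of these compounds alone.

In a physicochemical assay for lipophilicity, at pH 7.4 (a lower number here means a more polar compound, a higher number a more lipophilic compound), compound 2 `CO[C@H](C[C@H](CCN1CCCC(CO)C1)C(=O)NO)c1ccc(F)cc1` gives < 3, which is a limit and not a number. Compound 1 `Cc1ccc(CNCCCC[C@@H](Nc2cc(C)c(F)c(C)c2)C(=O)NO)cc1` also gives a limit, < 3. Compound 3 `CO[C@H](C[C@H](CCN1CCCC(Cc2ccc(F)cc2)C1)C(=O)NO)c1ccc(F)cc1` gives a limit too, < 3. The next change, to compound 4 `CO[C@H](C[C@H](CCN1CCNCC1)C(=O)NO)c1ccc(F)cc1`, puts piperazin-1-yl in place of 3-(hydroxymethyl)piperidin-1-yl on a saturated chain carbon, three bonds along the chain from a carbonyl carbon. Among the compounds with values here, the one measured step that bears on it is a step that the two limits leave unreadable from compound 2 to compound 3, and it gives neither a size nor a direction. The available evidence is the limit of < 3 in this assay, at which 3 of the 3 values shown sit. The expected step that the limit leaves unreadable from compound 2 to compound 4 is therefore only a loose estimate, and a further limit is likely. For compound 4 the estimated value is 1, expected to fall between 0 and 2.2.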

Compound 4, distribution coefficient: < 3
Compound 4 gave a limit, no number; the forecaster's own chance of this, stated with the estimate: 85%; the middle value does not contradict the limit.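

In this assay compound 4 gives < 3, a limit and not a number. Within the data shown here, no step from compound 2 to compound 4 can be read. The compounds shown leave open whether piperazin-1-yl in place of 3-(hydroxymethyl)piperidin-1-yl changes the read-out at all.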